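The compounds below may be only part of what the source reports. "The series", "measured", "known", "first", "only" and "open" are said of these compounds alone.

In a functional assay on A549 cells (Homo sapiens) for antiproliferative activity, read by MTT assay, with a stated time of 48 h (on this read-out lower numbers stand for stronger inhibition and higher numbers for weaker inhibition), compound 1 `Fc1ccc(-c2nn(-c3ccccc3)cc2-c2nc3cc(Cl)ccc3[nH]2)cc1` gives 1320 nM. Compound 2 `Fc1ccc(-c2nn(-c3ccccc3)cc2-c2nc3cc(Cl)c(Cl)cc3[nH]2)cc1` carries chloro in place of hydrogen on an aromatic carbon and gives 15700 nM, which makes a 12-fold higher number from compound 1 to compound 2 (1.08 log units; beyond the scatter). Compound 3 `Cc1cc2nc(-c3cn(-c4ccccc4)nc3-c3ccc(Cl)cc3)[nH]c2cc1C` gives 17700 nM, within the scatter of compound 2. Compound 2 therefore stands level with compound 3, and its number is well above that of compound 1.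

The next structure is compound 4 `COc1ccc(-c2nn(-c3ccccc3)cc2-c2nc3cc(Cl)c(Cl)cc3[nH]2)cc1`, reached from compound 2 by one change: methoxy in place of fluoro on an aromatic carbon. This is methoxy in place of fluoro on an aromatic carbon, para to a large group, or 4-fluorophenyl to 4-methoxyphenyl. For the measured compounds named here, no measured step covers this change. Going by the values given here, the only single-place step, a 12-fold higher number from compound 1 to compound 2 (1.08 log units; beyond the scatter), is a different substitution at a different place, so it gives no direction here. It does show that one small substitution in this series can move the number a long way, which argues for a wide range. Compound 3 differs from compound 2 in more than one place and gives no clean comparison.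

With no direction supported, the expected result is a 1.0-fold lower number from compound 2 to compound 4 (0.02 log units; within the scatter), with no shift beyond the scatter anticipated. For compound 4 the estimated value is 15000 nM, with an expected range of 4000 nM to 50000 nM.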

Compound 4, half-maximal inhibitory concentration: 7330 nM
Beside the measured number, compound 4's estimate is 2.0-fold (0.31 log units) above it; the measured number falls inside the stated range.
By their numbers in this assay, from the lowest: compound 1; then compound 4; then compounds 2 and 3 (each within the scatter of the next).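

For the compounds shown here, the change from 4-fluorophenyl to 4-methoxyphenyl gives the first reading at this position: in this assay there is a 2.1-fold lower number from compound 2 to compound 4 (0.33 log units; beyond the scatter), a modest step but one beyond the scatter. The earlier step, a 12-fold higher number from compound 1 to compound 2 (1.08 log units; beyond the scatter), lay at a different place, so it is only now seen that this aromatic carbon, para to a large group, also affects the number, with methoxy, which brings two heavy atoms and one hydrogen-bond acceptor, giving a lower number than fluoro, which brings one heavy atom and no acceptor. Nothing available bears on why the number moves in this direction.

The compounds shown leave open whether the step would keep its direction and size on the core of compound 1, since this single pair reads the change only on the core of compound 2. They also leave open how other groups at this same place would compare with methoxy and fluoro, such as a longer ether like ethoxy, a hydroxyl or an amine.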